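Removing one fluoro group from compound 2

The compounds below may be only part of what the source reports. "The series", "measured", "known", "first", "only" and "open" are said of these compounds alone.

Measured so far in a functional assay on NCI-H460 cells (Homo sapiens) for inhibition; a lower number here means a stronger inhibitor of growth, a higher number a weaker inhibitor of growth
Compound 1 `Nc1ccc(-c2nc3cc(F)ccc3s2)cc1Cl` gives 40 nM
Compound 2 `Cc1cc(-c2nc3cccc(F)c3s2)ccc1N` gives 4200 nM

Compound 2 holds the higher of the two numbers, so it is the weaker growth inhibitor of this pair. Compound 3 `Cc1cc(-c2nc3ccccc3s2)ccc1N` differs from compound 2 in one place (hydrogen in place of fluoro on an aromatic carbon), with hydrogen in place of fluoro on an aromatic carbon. For the measured compounds named here, no measured pair shows this change alone, so any expectation stays loose. Compound 1 at 40 nM shows that a much lower number is reachable, although it differs from compound 2 in more than one place. The expected change is a 4.2-fold lower number from compound 2 to compound 3 (0.62 log units; beyond the scatter) and would be a moderate move toward a lower number. For compound 3 the estimated value is 1000 nM with an expected range from 80 nM to 10000 nM in repeated measurements.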

Compound 3, concentration for 50% growth inhibition: 29500 nM
Estimate against measurement, compound 3: 30-fold (1.47 log units) below; measured number above the stated range.
By their numbers in this assay, from the lowest: compound 1; then compound 2; then compound 3.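

In this assay replacing fluoro with hydrogen on this aromatic carbon gives a 7.0-fold higher number from compound 2 to compound 3 (0.85 log units; beyond the scatter) and so, in this pair, the fluoro group goes with stronger growth inhibition than hydrogen. For the compounds shown here, this is the first comparison here that isolates a single change, and it shows that one atom at this place can shift the number beyond the usual scatter. On these data alone, whether a methoxy group or a nitrile at this carbon would go further remains open. Nothing shown accounts for the step.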